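The source may report more compounds than this note shows. Statements on the series, on what has been measured and on what is new or still open speak of the compounds shown alone.

Compound 1 `CS(=O)(=O)Nc1ccc(-c2nc3ccccc3o2)cc1` carries a methyl on its sulfonyl sulfur. In an assay on isolated protein for inhibition of malate dehydrogenase, mitochondrial (Sus scrofa), with stated times of 45 min and 30 min (on this read-out lower numbers stand for stronger inhibition and higher numbers for weaker inhibition), compound 1 gives only a limit, > 63000 nM, and no number. Compound 2 `O=S(=O)(Nc1ccc2oc(-c3ccccc3)nc2c1)c1ccc(Cl)c(C(F)(F)F)c1` likewise reaches only the limit, > 63000 nM. Compound 3 `CCc1ccc(S(=O)(=O)Nc2ccc3oc(-c4ccccc4)nc3c2)cc1` also sits at the limit, > 63000 nM. All three values rest at the limit of > 63000 nM in this assay, at which 3 of the 3 values shown sit; no compound shown yields a real number, so no measured step exists to guide an expectation. Compound 4 `O=S(=O)(Nc1ccc(-c2nc3ccccc3o2)cc1)c1ccc(Cl)c(Cl)c1` differs from compound 1 in one place: 3,4-dichlorophenyl in place of methyl on a sulfonyl sulfur. Compounds 2 and 3 already carry a six-membered aromatic ring of carbon only on their sulfonyl sulfur and still remain at the limit. The step is therefore expected to be none beyond the scatter, a step that the limit leaves unreadable from compound 1 to compound 4. Compound 4 is expected to give about 70000 nM, between 20000 nM and 250000 nM, most likely again as a limit.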

Compound 4, half-maximal inhibitory concentration: > 63000 nM
Compound 4 gave a limit, no number (the forecaster's own chance of this, stated with the estimate: 75%); the middle value is on the limit's open side.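

Among these compounds, compound 1 and compound 4 both give only a limit and no number, so no step between them can be read: the limit of > 63000 nM in this assay, at which 4 of the 4 values shown sit. In this assay, the compounds shown leave open whether any group on the sulfonyl sulfur would give a real number.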